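Benzyl in Place of Methyl on the Pyrazole of Compound 3

The source may report more compounds than this note shows. Statements on the series, on what has been measured and on what is new or still open speak of the compounds shown alone.

Measured so far:
compound 1, `C[C@@H](O[C@H]1CN2C(=O)C=C(c3ccc(CO)cc3)CC2[C@@H]1c1ccc(F)cc1)c1cc(C(F)(F)F)cc(C(F)(F)F)c1`, 0.39 nM
compound 2, `COc1cc(C2=CC(=O)N3C[C@H](O[C@H](C)c4cc(C(F)(F)F)cc(C(F)(F)F)c4)[C@@H](c4ccc(F)cc4)C3C2)ccn1`, 1.1 nM
compound 3, `C[C@@H](O[C@H]1CN2C(=O)C=C(c3cnn(C)c3)CC2[C@@H]1c1ccc(F)cc1)c1cc(C(F)(F)F)cc(C(F)(F)F)c1`, 0.13 nM

In an assay on CHO cells for displacement of a labelled ligand from Substance-P receptor (Homo sapiens) (on this read-out higher numbers stand for weaker inhibition and lower numbers for stronger inhibition), compound 3 gives the lowest number of the three, and the gaps to the other two are beyond the scatter: a 3.0-fold lower number from compound 1 to compound 3 (0.48 log units; beyond the scatter) and an 8.5-fold lower number from compound 2 to compound 3 (0.93 log units; beyond the scatter). The third step, a 2.8-fold higher number from compound 1 to compound 2 (0.45 log units; beyond the scatter), is of similar size. Compound 4 is `C[C@@H](O[C@H]1CN2C(=O)C=C(c3cnn(Cc4ccccc4)c3)CC2[C@@H]1c1ccc(F)cc1)c1cc(C(F)(F)F)cc(C(F)(F)F)c1`, differing from compound 3 by phenyl in place of hydrogen on a saturated chain carbon bound to an aromatic nitrogen. Within the data shown here, none of the measured steps touches this position; all three exchange the whole aromatic group on the double-bonded ring carbon, so they set only a scale for what a single change can do here. A small weakening is expected, a 2.3-fold higher number from compound 3 to compound 4 (0.36 log units; beyond the scatter). Compound 4 is therefore estimated at 0.3 nM, within a range of 0.08 nM to 1.5 nM.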

Compound 4, half-maximal inhibitory concentration: 1.9 nM
Compound 4: the middle estimate sits 6.3-fold (0.80 log units) below what was measured; measured number outside the range, above it.
By their numbers in this assay, from the lowest: compound 3; then compound 1; then compounds 2 and 4 (each within the scatter of the next).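

In this assay, replacing methyl with benzyl gives a 15-fold higher number from compound 3 to compound 4 (1.16 log units; beyond the scatter), so a change on this saturated chain carbon alone, with the pyrazole kept, moves the number substantially. The benzyl group also removes the pyrazole series' lead over the other aromatic groups: the steps read a 1.7-fold higher number from compound 2 to compound 4 (0.24 log units; within the scatter) and a 4.9-fold higher number from compound 1 to compound 4 (0.69 log units; beyond the scatter). Nothing available here accounts for this loss. As far as these compounds go, what remains open is whether an ethyl group, in place of the methyl of compound 3, would stay close to compound 3 or move towards compound 4, and how a longer chain ending in an amine would read.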